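This account rests on a few compounds, and the source may have more. Where it says the series, first, only, none or still open, it means among the compounds named here.

Compound 1 `CC(C)NC(=O)CC(c1ccc(-c2ccc3cccc(F)c3c2)[nH]c1=O)C(C)C` is known in an ADME assay on microsomes from liver (Mus musculus) for metabolic stability (on this read-out lower numbers stand for a shorter-lived compound and higher numbers for a longer-lived compound), only as a limit of the assay, < 0.0667 h, not as a number (the limit of < 0.0667 h in this assay, at which 1 of the 2 values shown sits). Compound 2 `CC(C)C(c1noc(=O)[nH]1)c1ccc(-c2ccc3cccc(F)c3c2)[nH]c1=O` likewise sits at a limit in this assay, > 3 h (the limit of > 3 h in this assay, at which 1 of the 2 values shown sits). Within the data shown here, the single measured step, an at least 44-fold higher number from compound 1 to compound 2 (1.65 log units; beyond the scatter), is large. Compound 3 `CC(C)C(c1cnc(N)s1)c1ccc(-c2ccc3cccc(F)c3c2)[nH]c1=O` differs from compound 1 by 2-amino-1,3-thiazol-5-yl in place of (isopropylcarbamoyl)methyl on a saturated chain carbon bound to an aromatic carbon and a saturated chain carbon. As in the step from compound 1 to compound 2, the (isopropylcarbamoyl)methyl chain gives way to a five-membered aromatic ring, so a large upward step in this assay is expected. Compound 3 is expected to give 1.5 h, in the range 0.3 h to 3 h. The expected step is an at least 22-fold higher number from compound 1 to compound 3 (1.35 log units; beyond the scatter).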

Compound 3, half-life: 0.08 h
Compound 3: middle estimate off by 19-fold (1.27 log units), on the high side; measured number outside the range, below it.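

In this assay, replacing the ring of compound 2 gives an at least 37-fold lower number from compound 2 to compound 3 (1.57 log units; beyond the scatter), so a five-membered aromatic ring on this saturated chain carbon does not by itself secure a long half-life. Compound 2 is a limit of the assay: the limit of > 3 h in this assay, at which 1 of the 3 values shown sits. Against the (isopropylcarbamoyl)methyl chain, the change gives only an at least 1.1-fold higher number from compound 1 to compound 3 (0.07 log units; that floor lies within the scatter), a floor because compound 1 is a limit: the limit of < 0.0667 h in this assay, at which 1 of the 3 values shown sits.

The compounds shown do not tell whether the amino group or the thiazole ring sets the gap from compound 2. Nor do they show how a plain 1,3-thiazol-5-yl or a carboxylic acid on this carbon would read.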